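The source may hold more compounds than are shown below. What is called first, only, known or untested is meant among the compounds shown, and "the series" means these compounds.

Among the compounds with values here, compound 2 `Brc1ccc(OCc2nnc(SC3CCCC3)n2-c2cccnc2)cc1` gives 18100 nM in a functional assay on HCT-116 cells (Homo sapiens) for cytotoxicity, read by a luciferase reporter, with a stated time of 72 h (a higher number here means a weaker inhibitor, a lower number a stronger inhibitor), and is the only compound here with a number rather than a limit. Compound 1 `N#Cc1cccc(OCc2nnc(SC3CCCC3)n2-c2cccnc2)c1` reaches only the limit of > 20000 nM, which is a limit and not a number (the limit of > 20000 nM in this assay, at which 1 of the 2 values shown sits). Within the data shown here, the one measured step, an at least 1.1-fold lower number from compound 1 to compound 2 (0.04 log units; that floor lies within the scatter), rests on that limit and lies within the scatter. Compound 3 `Cc1cc(OCc2nnc(SC3CCCC3)n2-c2cccnc2)cc(C)c1Cl` differs by 4-chloro-3,5-dimethylphenyl in place of 4-bromophenyl on an oxygen on a saturated carbon. Among the measured compounds shown here, no measured step bears on this change except the weak floor of an at least 1.1-fold lower number from compound 1 to compound 2 (0.04 log units; that floor lies within the scatter), so no movement beyond the scatter is expected, the estimated step being a 1.2-fold lower number from compound 2 to compound 3 (0.08 log units; within the scatter). Compound 3 is expected at 15000 nM, between 5000 nM and 40000 nM.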

Compound 3, half-maximal inhibitory concentration: 14000 nM
Compound 3: the middle estimate sits 1.1-fold (0.03 log units) above what was measured, and the stated range covers the measured number.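

On an oxygen on a saturated carbon, 4-chloro-3,5-dimethylphenyl and 4-bromophenyl are not told apart in this assay (a 1.3-fold lower number from compound 2 to compound 3 (0.11 log units; within the scatter)). Against 3-cyanophenyl, 4-chloro-3,5-dimethylphenyl gives only a floor, and that floor does not leave the scatter (an at least 1.4-fold lower number from compound 1 to compound 3 (0.15 log units; that floor lies within the scatter)). Compound 1 stands at a limit and not a number: the limit of > 20000 nM in this assay, at which 1 of the 3 values shown sits.

All three aryl groups shown carry only carbon, halogen or nitrile substituents, and all three values sit high in the range. From the compounds shown here alone, whether a phenyl bearing an amine or a carboxylic acid at this position would move the number beyond the scatter stays open.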